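Phenyl for dichlorophenyl in the thiocyanate series

The source may report more compounds than this note shows. Statements on the series, on what has been measured and on what is new or still open speak of the compounds shown alone.

Compound 2 `N#CSc1c(-c2ccc(Cl)cc2Cl)nc2sc(Cc3ccc(Cl)cc3)nn12` carries a cyanosulfanyl group and a 2,4-dichlorophenyl on the shared core. Among the compounds with values here, in a functional assay on L1210 cells (Mus musculus) for cytotoxicity, with a stated time of 48 h (on this read-out lower numbers stand for stronger inhibition and higher numbers for weaker inhibition), compound 2 gives 49000 nM, the only numeric value in this set. Compound 1 `Clc1ccc(Cc2nn3c(Br)c(-c4ccccc4)nc3s2)cc1` differs in more than one place, bearing bromine in place of the cyanosulfanyl group and phenyl in place of 2,4-dichlorophenyl. In this assay compound 1 gives > 250000 nM, which is a limit of the assay rather than a number. Beyond that, the limit of > 250000 nM in this assay, at which 1 of the 2 values shown sits, is the only other point available. Within the data shown here, compound 1 and compound 2 differ in two places, and no single step between measured compounds can be stated.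

Compound 3 `N#CSc1c(-c2ccccc2)nc2sc(Cc3ccc(Cl)cc3)nn12` is the untested member. Its change from compound 2 is phenyl in place of 2,4-dichlorophenyl on an aromatic carbon, with the cyanosulfanyl group retained. Among the measured compounds shown here, with no measured step of this kind, a modest loss is expected, estimated as a 2.4-fold higher number from compound 2 to compound 3 (0.39 log units; beyond the scatter) toward weaker inhibition. Compound 3 is expected to give an estimated 120000 nM, range 40000 nM to 300000 nM, with a fair chance that only a limit is reported.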

Compound 3, half-maximal inhibitory concentration: 24000 nM
For compound 3 the middle estimate is 5.0-fold (0.70 log units) above the measured one; measured number below the stated range.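

In this assay, within the data shown here, phenyl in place of 2,4-dichlorophenyl on this aromatic carbon gives a 2.0-fold lower number from compound 2 to compound 3 (0.31 log units; beyond the scatter), the first readable step at this position; in this pair the change runs toward stronger inhibition, so the two chlorines are not required for the read-out in the thiocyanate series. Among these compounds, with phenyl held constant, compound 3 also makes the other change readable, as cyanosulfanyl in place of bromo gives an at least 10-fold lower number from compound 1 to compound 3 (1.01 log units; beyond the scatter), a larger shift than the one from the aryl change. Compound 1 is a limit of the assay and not a number, and the size of that step rests on this limit: the limit of > 250000 nM in this assay, at which 1 of the 3 values shown sits.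

Among the compounds shown here, the single pair at this position cannot tell whether one chlorine alone accounts for the step, nor how a phenyl carrying an amine or a carboxylic acid, or a longer alkyl chain in place of the aryl ring, would read out. Going by these compounds, the step from bromo to cyanosulfanyl is likewise a single pair on a phenyl background, so whether it holds with 2,4-dichlorophenyl, and how a plain nitrile or an amine would compare at that carbon, stays open.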